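Phenyl in place of dimethylamino: an expected step

The compounds below may be only part of what the source reports. "The series", "measured", "known", "first", "only" and "open" are said of these compounds alone.

compound 1 `COc1cc2nc(N3CCN(c4ncccn4)CC3)nc(N)c2cc1OC`: 0.26 nM
compound 2 `CCCOc1ccnc(N2CCN(c3nc(N)c4cc(OC)c(OC)cc4n3)CC2)n1`: 0.32 nM
compound 3 `COc1cc2nc(N3CCN(c4nccc(N(C)C)n4)CC3)nc(N)c2cc1OC`: 0.27 nM

In an assay on brain for binding affinity to Adrenergic receptor alpha-1 (Rattus norvegicus) (a lower number here means a stronger inhibitor, a higher number a weaker inhibitor), compound 3 stands second highest of the three numbers, but its nearest neighbour is compound 1 and its furthest is compound 2, and both gaps are within the scatter. Compound 4 `COc1cc2nc(N3CCN(c4nccc(-c5ccccc5)n4)CC3)nc(N)c2cc1OC` differs from compound 3 in one place: phenyl in place of dimethylamino on an aromatic carbon. Going by the values given here, the steps that bear on this position are a 1.0-fold higher number from compound 1 to compound 3 (0.02 log units; within the scatter) and a 1.2-fold lower number from compound 2 to compound 3 (0.07 log units; within the scatter), each within the scatter, though neither adds a phenyl. On that basis the step of a 1.3-fold higher number from compound 3 to compound 4 (0.11 log units; within the scatter) is expected to stay small, with no direction beyond the scatter. For compound 4 the estimate in this assay is 0.35 nM, within a range from 0.12 nM to 1 nM.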

Compound 4, inhibition constant: 1.66 nM
For compound 4 the middle estimate is 4.7-fold (0.68 log units) below the measured one; measured number outside the range, above it.
By their numbers in this assay, from the lowest: compounds 1, 3 and 2 (each within the scatter of the next); then compound 4.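

In this assay, going by these compounds alone, hydrogen, propoxy and dimethylamino at this position gave numbers within the scatter of one another, whereas phenyl is the first group to give a higher number beyond it (a 6.4-fold higher number from compound 1 to compound 4 (0.81 log units; beyond the scatter); a 5.2-fold higher number from compound 2 to compound 4 (0.71 log units; beyond the scatter); a 6.1-fold higher number from compound 3 to compound 4 (0.79 log units; beyond the scatter)). All three steps are modest, and only phenyl brings a ring to this position. No evidence available here accounts for the change.

The compounds shown leave open whether another ring, such as cyclohexyl or pyridyl, would behave like phenyl. They also leave open how a phenyl carrying an amine or a carboxylic acid would compare.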